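Sulfonamide series: methoxy for methyl, compound 2 to compound 4

The compounds below may be only part of what the source reports. "The series", "measured", "known", "first", "only" and "open" are said of these compounds alone.

Compound 1, `O=S(=O)(Nc1ccc2oc(-c3ccc(NS(=O)(=O)c4cccc5nonc45)cc3)nc2c1)c1ccc(Cl)s1`: in an assay on cells for inhibition of HSP60/HSP10 (Homo sapiens), with a stated time of 60 min (on this read-out lower numbers stand for stronger inhibition and higher numbers for weaker inhibition), compound 1 gives 13000 nM.
Compound 2, `Cc1ccccc1S(=O)(=O)Nc1ccc2oc(-c3ccccc3)nc2c1`: in this assay compound 2 gives only the assay limit > 100000 nM.
Compound 3, `O=S(=O)(Nc1ccc(-c2nc3ccccc3o2)cc1)c1ccccc1F`: in this assay compound 3 gives only the assay limit > 100000 nM.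

Compound 2 stands at the limit, as does compound 3 (the limit of > 100000 nM in this assay, at which 2 of the 3 values shown sit), and only compound 1 yields a number. Compound 4, `COc1ccccc1S(=O)(=O)Nc1ccc2oc(-c3ccccc3)nc2c1`, differs from compound 2 by methoxy in place of methyl on an aromatic carbon. Among the compounds with values here, no measured step of this kind exists among the three compounds, so no shift beyond the usual scatter is expected, and the expected step is a number no higher from compound 2 to compound 4 (the limit leaves the size open). Compound 4 is therefore estimated at 100000 nM, between 30000 nM and 300000 nM, with a limit rather than a number the most likely outcome.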

Compound 4, half-maximal inhibitory concentration: > 100000 nM
Compound 4: no number, only a limit; the forecaster's own chance of this, stated with the estimate: 75%; the middle value lies on the limit itself.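

No step from compound 2 to compound 4 can be read, with both compounds giving only a limit: the limit of > 100000 nM in this assay, at which 3 of the 4 values shown sit.

From the compounds shown here alone, whether methoxy in place of methyl on an aromatic carbon changes inhibition at all remains open.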